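This account rests on a few compounds, and the source may have more. Where it says the series, first, only, none or still open, it means among the compounds named here.

Compound 1 `CC(C)(C)NC(=O)c1cc(-c2ccc(Cl)cc2Cl)n[nH]1` is one of three compounds from the same core whose inhibition has been measured in an assay on isolated protein for inhibition of alkaline phosphatase, tissue-nonspecific isozyme (Homo sapiens) (a lower number here means a stronger inhibitor, a higher number a weaker inhibitor), where compound 1 gives 398 nM. Compound 2 `O=C(c1cc(-c2ccc(Cl)cc2Cl)n[nH]1)N1CCOCC1` gives 574 nM in this assay, and compound 3 `CN(C)C(=O)c1cc(-c2cc(F)c(Cl)cc2Cl)n[nH]1` gives 324 nM. Among these three numbers compound 1 stands second highest, with compound 3 nearest and compound 2 furthest, and both gaps fall within the scatter of repeated measurements.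

Compound 4 `O=C(NCCCCO)c1cc(-c2ccc(Cl)cc2Cl)n[nH]1` has not yet been measured. It differs from compound 1 at the amide: 4-hydroxybutyl in place of tert-butyl on an amide-type nitrogen. Among the measured compounds shown here, the only measured step that touches the same position is the exchange of the amide substituent from compound 1 to compound 2, which gave a 1.4-fold higher number from compound 1 to compound 2 (0.16 log units; within the scatter); compound 3 carries a different amide as well as an added fluorine, so no single step can be read from it. On this basis the change to the hydroxybutyl chain is expected to leave the number essentially where it is, with no step beyond the scatter, so that compound 4 is estimated at 450 nM in this assay, within a range from 180 nM to 1100 nM, corresponding to an expected step of a 1.1-fold higher number from compound 1 to compound 4 (0.05 log units; within the scatter).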

Compound 4, half-maximal inhibitory concentration: 35 nM
Compound 4: middle estimate off by 13-fold (1.11 log units), on the high side, outside the stated range (below it).
By their numbers in this assay, from the lowest: compound 4; then compounds 3, 1 and 2 (each within the scatter of the next).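

In this assay the amide position proves far more sensitive than the earlier exchange showed: 4-hydroxybutyl in place of tert-butyl on the amide-type nitrogen gives an 11-fold lower number from compound 1 to compound 4 (1.06 log units; beyond the scatter) while morpholin-4-yl in place of (tert-butyl)amino had stayed within the scatter. (4-Hydroxybutyl)amino in place of morpholin-4-yl gives a 16-fold lower number from compound 2 to compound 4 (1.21 log units; beyond the scatter) so that compound 4 stands apart from both earlier amides, which remain within the scatter of each other. No measurement at hand explains this large step.

The compounds shown leave open whether the step comes from the terminal hydroxyl or from the chain itself, which a plain butyl chain, a shorter or longer hydroxyalkyl chain or a methoxy end would separate. Also open, from the compounds shown here alone, is whether an amine or a carboxylic acid could replace the hydroxyl, and whether the same chain does as much on the core of compound 3.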